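Methyl on the core of compound 1

The source may report more compounds than this note shows. Statements on the series, on what has been measured and on what is new or still open speak of the compounds shown alone.

Within the data shown here, in a functional assay on HCT-116 cells (Homo sapiens) (a higher number here means a weaker inhibitor of growth, a lower number a stronger inhibitor of growth), compound 1 (`Oc1cc(-c2ccc(Cl)cc2)nc2ncccc12`) gives 32400 nM, the higher of the two numbers so far, and compound 2 (`Cc1cnc2nc(-c3ccc(Cl)cc3)cc(O)c2c1`) gives 2820 nM. Compound 3 (`Cc1ccnc2nc(-c3ccc(Cl)cc3)cc(O)c12`) has methyl in place of hydrogen on an aromatic carbon of compound 1 (methyl in place of hydrogen on an aromatic carbon), ortho to a fused ring, meta to a fused ring and opposite the ring nitrogen. Among the measured compounds shown here, one measured step bears on this, the same exchange at a different carbon: an 11-fold lower number from compound 1 to compound 2 (1.06 log units; beyond the scatter), a large step. A lower number is expected, probably by a smaller step. The estimate for compound 3 is 9000 nM, with a range of 2500 nM to 30000 nM. The expected change is a 3.6-fold lower number from compound 1 to compound 3 (0.56 log units; beyond the scatter).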

Compound 3, concentration for 50% growth inhibition: 3720 nM
For compound 3 the middle estimate is 2.4-fold (0.38 log units) above the measured one; the measured number falls inside the stated range.
By their numbers in this assay, from the lowest: compounds 2 and 3 (each within the scatter of the next); then compound 1.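

In this assay, methyl in place of hydrogen on this aromatic carbon, opposite the ring nitrogen, gives an 8.7-fold lower number from compound 1 to compound 3 (0.94 log units; beyond the scatter) and so lowers the number here too. Methyl now lowers the number at two carbons of the shared core, and compounds 2 and 3 lie within the scatter of each other, so the two placements are not separated. Nothing available explains either step.

Open, as far as these compounds go, is whether a group other than methyl on this carbon, such as an amine, a methoxy group or a longer chain, would lower the number as well.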